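Solubility of nitroimidazole sulfonamides: a diethylamino variant

This account rests on a few compounds, and the source may have more. Where it says the series, first, only, none or still open, it means among the compounds named here.

Measured compounds:
compound 1, `O=[N+]([O-])c1cncn1CS(=O)(=O)NCCO`, 23700000 nM in a physicochemical assay for solubility, read by HPLC; a higher number here means a more soluble compound, a lower number a less soluble compound
compound 2, `O=[N+]([O-])c1cn(CCS(=O)(=O)NCCO)cn1`, > 100000000 nM
compound 3, `COCCCNS(=O)(=O)CCn1c([N+](=O)[O-])cnc1C`, 17000000 nM

Three compounds built around a nitroimidazole linked to a sulfonamide have been measured for solubility. Compound 3 gives 17000000 nM in this assay, and compound 1 gives 23700000 nM, the two sitting within the usual scatter of each other. Compound 2 reaches (the limit of > 100000000 nM in this assay, at which 1 of the 3 values shown sits), so its result is a limit of the method and not a number.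

The next compound, compound 4 (`CCN(CC)CCNS(=O)(=O)CCn1c([N+](=O)[O-])cnc1C`), has not yet been measured. It differs from compound 3 in one place: diethylamino in place of methoxymethyl on a saturated chain carbon, two bonds along the chain from a sulfonamide nitrogen. Among the compounds with values here, no pair of measured compounds shows this kind of exchange, so the size of the step rests on expectation alone. The account expects compound 4 to move upward in this assay, though the step may not rise beyond the scatter; the expected step is a 2.4-fold higher number from compound 3 to compound 4 (0.37 log units; beyond the scatter). The estimate for compound 4 in this assay is therefore 40000000 nM, with a range from 12000000 nM to 130000000 nM.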

Compound 4, solubility: 45700000 nM
The estimate for compound 4 lay 1.1-fold (0.06 log units) below the measured number; low and high end bracket the measured number.
By their numbers in this assay, from the lowest: compounds 3, 1 and 4 (each within the scatter of the next, the first and the last beyond it). At a limit, above all of these: compound 2.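

In this assay, within the data shown here, this is the first exchange that can be read at this place, on a saturated chain carbon, two bonds along the chain from a sulfonamide nitrogen: diethylamino in place of methoxymethyl gives a 2.7-fold higher number from compound 3 to compound 4 (0.43 log units; beyond the scatter). The pair shows that a group of 5 heavy atoms can stand where one of 3 stood, with the same count of hydrogen-bond acceptors, and the number still goes up rather than down. Compound 2 remains a limit and not a number, so it gives no size for comparison: the limit of > 100000000 nM in this assay, at which 1 of the 4 values shown sits.

A single pair cannot tell whether the step goes with the amine nitrogen or with the two ethyl groups on it. As far as these compounds go, a smaller dimethylamino, a morpholine ring or a carboxylic acid at the same place, or a longer chain before the amine, remains open.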